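This account rests on a few compounds, and the source may have more. Where it says the series, first, only, none or still open, it means among the compounds named here.

Measured so far in a functional assay on A549 cells (Homo sapiens) for inhibition, read by sulforhodamine B assay, with a stated time of 48 h; on this read-out higher numbers stand for weaker inhibition of growth and lower numbers for stronger inhibition of growth:
compound 1 `COC1=CC(=O)C(C/C=C(\C)CC/C=C(\C)CCC=C(C)C)=C(C)C1=O`: > 30000 nM
compound 2 `COC1=C(OC)[C@H](OC(C)=O)[C@H](C/C=C(\C)CC/C=C(\C)C[C@H](O)/C=C(\C)C(=O)O)[C@@H](C)C1=O`: > 30000 nM

Both values are limits of this assay rather than numbers. Compound 2 thus stands at the limit, as does every value shown; (the limit of > 30000 nM in this assay, at which 2 of the 2 values shown sit). Compound 3 `COC1=C(OC)[C@H](OC(C)=O)[C@H](C/C=C(\C)CC/C=C(\C)C[C@H](O)C=C(C)C)[C@@H](C)C1=O` differs from compound 2 by 2-methylprop-1-en-1-yl in place of 2-carboxyprop-1-en-1-yl on a saturated chain carbon bound to an oxygen on a saturated carbon and a saturated chain carbon. Among the measured compounds shown here, no step between measured compounds is available, so the size of this change cannot be anchored on the series. Compound 3 is expected to give about 30000 nM in this assay, within 8000 nM to 100000 nM. The step of a number no higher from compound 2 to compound 3 (the limit leaves the size open) is therefore estimated as none beyond the scatter, with a fair chance that only a limit is reported again.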

Compound 3, concentration for 50% growth inhibition: 20700 nM
Compound 3: the middle estimate sits 1.4-fold (0.16 log units) above what was measured; low and high end bracket the measured number.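

In this assay, among the compounds shown here, compound 3 is the first compound here to give a number rather than a limit, showing that the 2-methylprop-1-en-1-yl variant can be read at this position. The change gives an at least 1.4-fold lower number from compound 2 to compound 3 (0.16 log units; that floor lies within the scatter). Its full size stays unknown, as compound 2 is only a limit of the assay: the limit of > 30000 nM in this assay, at which 2 of the 3 values shown sit.

Whether the loss of the carboxy group alone accounts for the reading remains open. So does how an amine or a longer chain at this position would read.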